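Trimming a Butyl Chain to Methyl on a Shared Core

A few compounds are considered here, and "the series" means these few. Any claim that something is new, unique, unknown or untested is made for them only; others in the source may bear on it.

Compound 1 `CCCCNC(=O)N1CC1C#N` carries a butyl chain on an amide-type nitrogen. Among the compounds with values here, in a functional assay on A549 cells (Homo sapiens) for inhibition (a higher number here means a weaker inhibitor, a lower number a stronger inhibitor), compound 1 gives 18000 nM, the highest of the two numbers measured so far. Compound 2 `N#CC1CN1C(=O)NC1CCCCC1` gives 10000 nM in this assay, which lies within the scatter of compound 1, so the two cannot be ordered. Compound 3 `CNC(=O)N1CC1C#N` is not yet measured; it differs from compound 1 by hydrogen in place of propyl on a saturated chain carbon bound to an amide-type nitrogen. Within the data shown here, no measured pair shows such a step, so its size is open; a rise beyond the scatter, toward weaker inhibition, is expected. For compound 3 the estimated value is 40000 nM, ranging from 15000 nM to 120000 nM. The expected step of a 2.2-fold higher number from compound 1 to compound 3 (0.35 log units; beyond the scatter) means a loss of potency.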

Compound 3, half-maximal inhibitory concentration: 22000 nM
The estimate for compound 3 lay 1.8-fold (0.26 log units) above the measured number, and the stated range covers the measured number.
By their numbers in this assay, from the lowest: compounds 2, 1 and 3 (each within the scatter of the next, the first and the last beyond it).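

Replacing butyl with methyl gives a 1.2-fold higher number from compound 1 to compound 3 (0.09 log units; within the scatter), so in this assay this change has no readable effect and compound 1 and compound 3 cannot be ordered. At this position on the shared core, the propyl part of the butyl chain can therefore go without a measurable change in inhibition. Nothing at hand offers an explanation for this result. Still open, on these data alone, is whether a longer chain, such as octyl, or a chain ending in an amine or a carboxylic acid, would shift the number beyond the scatter.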